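The source may hold more compounds than are shown below. What is called first, only, known or untested is meant among the compounds shown, and "the series" means these compounds.

Going by the values given here, in a functional assay on MCF7 cells (Homo sapiens) for cytotoxicity, read by MTT assay, with a stated time of 72 h (on this read-out lower numbers stand for stronger inhibition and higher numbers for weaker inhibition), two compounds with a shared core have numbers so far. Compound 1 (`CC1(C)OCC(Cn2cc(Cn3c4c(c5ccccc53)C(=O)c3c[n+]([O-])c5ccccc5c3C4=O)nn2)O1`) gives 290 nM, and compound 2 (`O=C1c2c[n+]([O-])c3ccccc3c2C(=O)c2c1c1ccccc1n2Cc1cn([C@H]2C[C@H](O)[C@@H](CO)O2)nn1`) gives 530 nM. Among the compounds with values here, these two values lie within the scatter of each other, so compound 2 has no clear rank against its only neighbour. Compound 3 (`O=C1c2c[n+]([O-])c3ccccc3c2C(=O)c2c1c1ccccc1n2Cc1cn([C@@H]2O[C@H](CO)[C@@H](O)[C@H](O)[C@H]2O)nn1`) has not been measured yet. It differs from compound 2 by one group on an aromatic nitrogen: 3,4,5-trihydroxy-6-(hydroxymethyl)oxan-2-yl in place of 4-hydroxy-5-(hydroxymethyl)oxolan-2-yl on an aromatic nitrogen. Within the data shown here, one measured step bears on this swap, a 1.8-fold higher number from compound 1 to compound 2 (0.26 log units; within the scatter), which also exchanged the group on an aromatic nitrogen and stayed within the scatter. This single step is thin evidence, but on its basis no step beyond the scatter is expected in this assay, in either direction. The expected change is small, a 1.1-fold higher number from compound 2 to compound 3 (0.05 log units; within the scatter). Compound 3 is estimated at 600 nM, with an expected range from 220 nM to 1600 nM.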

Compound 3, half-maximal inhibitory concentration: 590 nM
The estimate for compound 3 lay 1.0-fold (0.01 log units) above the measured number; low and high end bracket the measured number.
By their numbers in this assay, from the lowest: compounds 1, 2 and 3 (each within the scatter of the next, the first and the last beyond it).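

In this assay, the oxolane group on the aromatic nitrogen can give way to the larger 3,4,5-trihydroxy-6-(hydroxymethyl)oxan-2-yl group, with its six-membered ring and additional hydrogen-bond donors, and the result is a 1.1-fold higher number from compound 2 to compound 3 (0.05 log units; within the scatter). Set against the (2,2-dimethyl-1,3-dioxolan-4-yl)methyl group, however, the same oxan-2-yl group gives a 2.0-fold higher number from compound 1 to compound 3 (0.31 log units; beyond the scatter), so this pair yields the first difference at this position to pass the scatter, though only modestly. Nothing available here explains these numbers.

All three groups at this position contain an oxygen-bearing ring, so they show little of how far the position's tolerance extends. From the compounds shown here alone, how a simple alkyl chain, an amine or a carboxylic acid in the same place would read in this assay remains open.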